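A few compounds are considered here, and "the series" means these few. Any claim that something is new, unique, unknown or untested is made for them only; others in the source may bear on it.

Measured so far in an assay for binding affinity to dual specificity mitogen-activated protein kinase kinase 4 (Homo sapiens), read by KINOMEscan, tested at 100 nM; a higher number here means a weaker effect of the compound at the concentration tested, a lower number a stronger effect:
- compound 1 `CCCS(=O)(=O)Nc1ccc(F)c(C(=O)c2n[nH]c3ncc(-c4ccccc4)cc23)c1F` gives 2.4%
- compound 2 `CCCS(=O)(=O)Nc1ccc(F)c(C(=O)c2n[nH]c3ncc(-c4ccccc4C)cc23)c1F` gives 7%
- compound 3 `CCCS(=O)(=O)Nc1ccc(F)c(C(=O)c2n[nH]c3ncc(-c4ccc(C(C)(C)C)cc4)cc23)c1F` gives 46%

All three share one core and differ only in the phenyl group hanging from it. Compound 3 stands highest of the three numbers, which here means the weakest effect: its step from compound 2 is a number 39 percentage points higher from compound 2 to compound 3 (beyond the scatter), and its step from compound 1 is a number 43.6 percentage points higher from compound 1 to compound 3 (beyond the scatter), both beyond the scatter. The small step of a number 4.6 percentage points higher from compound 1 to compound 2 (within the scatter) lies within the scatter.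

Compound 4 `CCCS(=O)(=O)Nc1ccc(F)c(C(=O)c2n[nH]c3ncc(-c4ccc(C(N)=O)cc4)cc23)c1F` is not yet measured. It differs from compound 3 by carbamoyl in place of tert-butyl on an aromatic carbon.

Going by the values given here, no measured pair shows a carbamoyl group, so no step matches this change directly. What the data do show is that placing a tert-butyl group on that ring, in the step of a number 43.6 percentage points higher from compound 1 to compound 3 (beyond the scatter), moved the number far upward; taking it away again is the part of the present change that the data speak to. On that ground the number for compound 4 is expected to fall, by a step of about a number 31 percentage points lower from compound 3 to compound 4 (beyond the scatter), with wide uncertainty since the entering group is new. The estimate for compound 4 in this assay is 15%, expected to lie between 2% and 55%.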

Compound 4, a percentage reported as activity, at one concentration (the size of the read-out at that concentration, not a potency): 0.15%
For compound 4 the middle estimate is 14.9 percentage points above the measured one; the whole stated range lies above it.
By their numbers in this assay, from the lowest: compounds 4, 1 and 2 (each within the scatter of the next); then compound 3.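

In this assay, carbamoyl in place of tert-butyl at this position gives a number 45.9 percentage points lower from compound 3 to compound 4 (beyond the scatter), so the large upward move seen with tert-butyl is not a penalty for every group placed here. Carbamoyl in place of hydrogen gives a number 2.3 percentage points lower from compound 1 to compound 4 (within the scatter), and 4-carbamoylphenyl in place of 2-methylphenyl gives a number 6.9 percentage points lower from compound 2 to compound 4 (within the scatter), so among the compounds shown, a group at this position can leave the number where the unsubstituted phenyl of compound 1 has it, with compound 3 the one that goes against this. Nothing at hand explains why these two groups at the same position behave so differently.

Where other groups at this position would fall remains open, for example a carboxylic acid, an amine, or a methyl group, and so does whether a longer chain on the amide nitrogen would keep the number this low. From the compounds shown here alone, compound 1, compound 2 and compound 4 also cannot be told apart by this single-concentration read-out, so any real difference in potency among them remains unknown.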